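Cyclohexyl to cycloheptyl: a small change to a ring

The compounds below may be only part of what the source reports. "The series", "measured", "known", "first", "only" and "open" are said of these compounds alone.

Compound 1 `O=C1Nc2c(ccc(F)c2F)C1(c1ccc(O)cc1)c1ccc(F)cc1`: 1910 ng.h/mL
Compound 2 `O=C1Nc2c(ccc(F)c2F)C1(c1ccc(O)cc1)c1cccs1`: 395 ng.h/mL
Compound 3 `O=C1Nc2c(ccc(F)c2F)C1(c1ccc(O)cc1)C1CCCCC1`: 3550 ng.h/mL

These three compounds share a core and differ only in one group on a saturated ring carbon. In an ADME assay on the whole organism (plasma) for pharmacokinetics, with Mus musculus as the target, at a dose of 5 mg/kg by the intravenous route (on this read-out higher numbers stand for higher exposure at the dose given and lower numbers for lower exposure), compound 3 gives 3550 ng.h/mL. This cannot be told apart from the number for compound 1, as the measured change is a 1.9-fold higher number from compound 1 to compound 3 (0.27 log units; within the scatter). Compound 2 is the clear outlier, with a 4.8-fold lower number from compound 1 to compound 2 (0.68 log units; beyond the scatter) and a 9.0-fold higher number from compound 2 to compound 3 (0.95 log units; beyond the scatter).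

Compound 4 `O=C1Nc2c(ccc(F)c2F)C1(c1ccc(O)cc1)C1CCCCCC1` has cycloheptyl in place of cyclohexyl on a saturated ring carbon, and so differs from compound 3 by a single change (cycloheptyl in place of cyclohexyl on a saturated ring carbon). Among the measured compounds shown here, no measured pair swaps one carbon-only saturated ring for another, so the evidence is indirect. The two large steps at this carbon both involve compound 2 and its thiophen-2-yl group, which compound 4 lacks. The closest guide is the step between compound 1 and compound 3, a 1.9-fold higher number from compound 1 to compound 3 (0.27 log units; within the scatter), which stayed within the scatter. No step beyond the scatter is therefore expected, and the expected step is a 1.2-fold lower number from compound 3 to compound 4 (0.07 log units; within the scatter). Compound 4 is estimated at 3000 ng.h/mL, with an expected range of 1200 ng.h/mL to 7000 ng.h/mL.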

Compound 4, area under the concentration-time curve: 694 ng.h/mL
Beside the measured number, compound 4's estimate is 4.3-fold (0.64 log units) above it; the measured number lies below the stated range.
By their numbers in this assay, from the lowest: compounds 2 and 4 (each within the scatter of the next); then compounds 1 and 3 (each within the scatter of the next).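

Going from cyclohexyl to cycloheptyl on this saturated ring carbon gives a 5.1-fold lower number from compound 3 to compound 4 (0.71 log units; beyond the scatter) in this assay and so shows that two carbon-only rings are not interchangeable here. Compound 2 also no longer stands alone at the low end, since a 1.8-fold higher number from compound 2 to compound 4 (0.24 log units; within the scatter) leaves compound 4 indistinguishable from it, and a low number at this carbon is therefore not peculiar to the thiophen-2-yl group. The step of a 2.8-fold lower number from compound 1 to compound 4 (0.44 log units; beyond the scatter) adds a further contrast. Compound 3 could not be told apart from compound 1, so swapping 4-fluorophenyl for a saturated ring can leave the number level or lower it, depending on which ring enters.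

The data offer nothing that explains the drop with cycloheptyl. Among the compounds shown here, with only two saturated rings in hand, a trend with ring size cannot be judged, and cyclopentyl or an open chain such as n-hexyl at the same carbon would help show whether cyclohexyl is an isolated high point or part of a wider pattern.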